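Chloro for Methoxy: Estimating Compound 4 in the Antiproliferative Assay

The compounds below may be only part of what the source reports. "The series", "measured", "known", "first", "only" and "open" are said of these compounds alone.

Compound 1 `COc1ccc(-c2nc(C)c(C(=O)CSc3nc(-c4cccc(OC)c4)c(C#N)c(=O)[nH]3)s2)cc1` gives 12.4% in a functional assay on U-87MG ATCC cells for antiproliferative activity against U-87 MG (Homo sapiens), read by MTT assay, with a stated time of 48 h, tested at 100 uM (a higher number here means a weaker effect of the compound at the concentration tested, a lower number a stronger effect), the second highest of three numbers. Its nearest neighbour is compound 3 `COc1cccc(-c2nc(SCC(=O)c3sc(-c4ccc(Cl)cc4)nc3C)[nH]c(=O)c2C#N)c1`, which gives 8.54%, and its furthest is compound 2 `COc1cccc(-c2nc(SCC(=O)c3sc(-c4ccccc4)nc3C)[nH]c(=O)c2C#N)c1`, which gives 21.8%; both gaps lie within the scatter. Compound 4 `COc1ccc(-c2nc(C)c(C(=O)CSc3nc(-c4cccc(Cl)c4)c(C#N)c(=O)[nH]3)s2)cc1` differs from compound 1 by chloro in place of methoxy on an aromatic carbon. The same change made on the other aromatic ring of the core gave a number 3.9 percentage points lower from compound 1 to compound 3 (within the scatter), and the related a number 13.3 percentage points lower from compound 2 to compound 3 (beyond the scatter) was only modest. The analyst therefore expects little movement beyond the scatter, leaning slightly lower, and estimates a step of a number 2.9 percentage points lower from compound 1 to compound 4 (within the scatter). The expected value for compound 4 is 9.5%, with a range of 2% to 18%.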

Compound 4, a percentage reported as activity, at one concentration (the size of the read-out at that concentration, not a potency): 40.6%
Estimate against measurement, compound 4: 31.1 percentage points below; measured number outside the range, above it.
By their numbers in this assay, from the lowest: compounds 3, 1 and 2 (each within the scatter of the next, the first and the last beyond it); then compound 4.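

In this assay the change to 3-chlorophenyl gives a number 28.2 percentage points higher from compound 1 to compound 4 (beyond the scatter) and so does not behave as it did on the other aromatic ring, where the same replacement gave a number 3.9 percentage points lower from compound 1 to compound 3 (within the scatter). The effect of chloro in place of methoxy therefore depends on which ring carries it, and at this place the swap weakens the effect of compound 1 at the concentration tested. No measurement shown explains the difference. On these data alone, whether a hydroxyl or an amine at this place would keep the number of compound 1 remains open, as does whether the shift comes from losing methoxy or from adding chloro.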